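The source may hold more compounds than are shown below. What is called first, only, known or untested is meant among the compounds shown, and "the series" means these compounds.

Compound 1 `O=C(NCc1cc(Cl)ccc1-n1cnnn1)[C@@H]1CC=NN1C(=O)[C@H](O)c1ccccc1` and compound 3 `CC(C)(C)C[C@@H](O)C(=O)N1N=CC[C@H]1C(=O)NCc1cc(Cl)ccc1-n1cnnn1` share one core; compound 2 `O=C([C@H](O)c1ccccc1)N1CC[C@@H]2C[C@@]21C(=O)NCc1cc(Cl)ccc1-n1cnnn1` and compound 4 `CC(C)(C)C[C@@H](O)C(=O)N1CC[C@@H]2C[C@@]21C(=O)NCc1cc(Cl)ccc1-n1cnnn1` share another, and the difference between the two cores is not broken down here. In a functional assay on a cell-free system (plasma, Homo sapiens), with a stated time of 3 min (a higher number here means a weaker inhibitor, a lower number a stronger inhibitor), compound 1 gives 840 nM, compound 3 gives 590 nM, and compound 2 gives 1100 nM. The change from compound 1 to compound 3 is neopentyl in place of phenyl on a saturated chain carbon bound to a carbonyl carbon and an oxygen on a saturated carbon, and it made a 1.4-fold lower number from compound 1 to compound 3 (0.15 log units; within the scatter). Compound 4 carries the same change on the core of compound 2: neopentyl in place of phenyl on a saturated chain carbon bound to a carbonyl carbon and an oxygen on a saturated carbon. A step of about that size is expected, a 1.4-fold lower number from compound 2 to compound 4 (0.14 log units; within the scatter), because the same change earlier gave a 1.4-fold lower number from compound 1 to compound 3 (0.15 log units; within the scatter). Starting from compound 2 at 1100 nM, compound 4 is therefore estimated to give 790 nM in this assay, with a range from 350 nM to 1800 nM.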

Compound 4, half-maximal inhibitory concentration: 620 nM
Compound 4: middle estimate off by 1.3-fold (0.11 log units), on the high side; the range from low to high includes it.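

In this assay, neopentyl in place of phenyl on the core of compound 2 gives a 1.8-fold lower number from compound 2 to compound 4 (0.25 log units; within the scatter). Set beside the same change on the other core, the two steps agree: the same change on two cores in this assay, a 1.4-fold lower number (0.15 log units; within the scatter) from compound 1 to compound 3 and a 1.8-fold lower number (0.25 log units; within the scatter) from compound 2 to compound 4, 1.2-fold (0.10 log units) apart, within the scatter of two such steps

So in these two pairs the change carries across the cores with no visible difference, but each step alone lies within the scatter, so neither pair shows that neopentyl and phenyl truly differ in this assay, and two cores say nothing about any other core.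

The compounds shown leave open what an amine, a carboxylic acid or a longer chain would give at this place. They also leave open whether a step beyond the scatter would carry across these two cores equally well.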